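The compounds below may be only part of what the source reports. "The series", "measured", "known", "first", "only" and "open" are said of these compounds alone.

Measured so far in a functional assay on a cell-free system (plasma, Homo sapiens) for inhibition, with Plasma (Rattus norvegicus) as the target; a lower number here means a stronger inhibitor, a higher number a weaker inhibitor:

- compound 1 `O=c1cc(N2CCNCC2)c2ccccc2o1` gives 250000 nM
- compound 2 `CCCOc1ccc2c(N3CCNCC3)cc(=O)oc2c1C` gives 7770 nM

Compound 2 holds the lower of these two numbers, which makes it the stronger inhibitor of the pair. The gap to compound 1 is well beyond the scatter of repeated measurements. Within the data shown here, with only two values, however, there is no trend to follow.

Compound 3 `CCOCOc1ccc2c(N3CCNCC3)cc(=O)oc2c1C` has not yet been measured. It differs from compound 2 in one place: ethoxy in place of ethyl on a saturated chain carbon bound to an oxygen on an aromatic ring. Seen one bond further out, the propoxy of compound 2 becomes ethoxymethoxy in compound 3.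

Among the measured compounds shown here, no measured pair shows what this swap does in this assay, so the expectation starts from compound 2 at 7770 nM. The change is confined to one chain, so no step beyond the scatter is expected, with only a slight lean towards a weaker inhibitor. The estimated step of a 1.2-fold higher number from compound 2 to compound 3 (0.06 log units; within the scatter) is therefore small and uncertain. The expected value for compound 3 is 9000 nM, within an estimated range of 3000 nM to 27000 nM.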

Compound 3, half-maximal inhibitory concentration: 1900 nM
Compound 3: middle estimate off by 4.7-fold (0.68 log units), on the high side, outside the stated range (below it).
By their numbers in this assay, from the lowest: compound 3; then compound 2; then compound 1.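

In this assay, replacing the propoxy of compound 2 with the ethoxymethoxy of compound 3 gives a 4.1-fold lower number from compound 2 to compound 3 (0.61 log units; beyond the scatter). Among these compounds, this is the first single-place step at this position, and it shows that a change confined to this chain can move the number beyond the usual scatter, here towards a stronger inhibitor. The swap adds an oxygen and one hydrogen-bond acceptor to the chain, but no measurement at hand explains the drop, and this one step cannot separate the part played by the oxygen from the part played by the extra heavy atom.

Still open, on these data alone, is whether the oxygen matters at all, and a butoxy chain, with carbon where compound 3 carries that oxygen, would be the direct comparison with compound 3. Also open, as far as these compounds go, is how far this position tolerates other kinds of group, such as an amine or a carboxylic acid on the same chain, and whether any of them would move the number in this assay in the same direction.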